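The source may report more compounds than this note shows. Statements on the series, on what has been measured and on what is new or still open speak of the compounds shown alone.

Measured compounds:
compound 1 `CC(CCNC(=O)c1c(Cl)cncc1Cl)N1CCC(C(Oc2cccc(Cl)c2)c2ccc(C(F)(F)F)cc2)CC1`, 8100 nM
compound 2 `CC(CCNC(=O)c1c(Cl)cncc1Cl)N1CCC(C(Oc2cccc(C(F)(F)F)c2)c2ccc(C(F)(F)F)cc2)CC1`, 7000 nM
compound 3 `CC(CCNC(=O)c1c(Cl)cncc1Cl)N1CCC(C(Oc2ccccc2C(F)(F)F)c2ccc(C(F)(F)F)cc2)CC1`, 12500 nM

All three were run in an ADME assay on PBMC cells (Homo sapiens) for cytotoxicity; a higher number here means that more compound is tolerated, a lower number that less compound is tolerated. Compound 4 `CC(CCNC(=O)c1c(Cl)cncc1Cl)N1CCC(C(Oc2ccccc2Cl)c2ccc(C(F)(F)F)cc2)CC1` has not yet been measured there. The change from compound 3 to compound 4 is chloro in place of trifluoromethyl on an aromatic carbon. The same kind of change has been made once before, from compound 2 to compound 1, as chloro in place of trifluoromethyl on an aromatic carbon, giving a 1.2-fold higher number from compound 2 to compound 1 (0.06 log units; within the scatter). The cores of those two pairs differ as 2-(trifluoromethyl)phenyl in place of 3-(trifluoromethyl)phenyl on an oxygen on a saturated carbon; around the place of the change, the group sits ortho to a large group in compound 3 but meta to a large group in compound 2. Within the measured set, the steps of a 1.5-fold higher number from compound 1 to compound 3 (0.19 log units; within the scatter) and a 1.8-fold higher number from compound 2 to compound 3 (0.25 log units; within the scatter) both stay within the scatter. For compound 4 a step of a 1.1-fold higher number from compound 3 to compound 4 (0.03 log units; within the scatter) is expected, resting on a 1.2-fold higher number from compound 2 to compound 1 (0.06 log units; within the scatter) in this assay. Compound 4 is therefore estimated at 13500 nM, expected to fall between 6500 nM and 27000 nM.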

Compound 4, half-maximal cytotoxic concentration: 4400 nM
Compound 4: the middle estimate sits 3.1-fold (0.49 log units) above what was measured, outside the stated range (below it).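

In this assay, chloro in place of trifluoromethyl on an aromatic carbon does not give one transferable step across these two cores: the same change on two cores in this assay, a 1.2-fold higher number (0.06 log units; within the scatter) from compound 2 to compound 1 and a 2.8-fold lower number (0.45 log units; beyond the scatter) from compound 3 to compound 4, 3.3-fold (0.52 log units) apart, beyond the scatter of two such steps

Beside a 2.8-fold lower number from compound 3 to compound 4 (0.45 log units; beyond the scatter), the other two new steps, a 1.6-fold lower number from compound 2 to compound 4 (0.20 log units; within the scatter) and a 1.8-fold lower number from compound 1 to compound 4 (0.27 log units; within the scatter), stay within the scatter, so only the trifluoromethyl-to-chloro step on the core of compound 3 stands out. With a single pair on each core, this shows that the step differs between these cores, but not which difference between them sets it, nor how it would behave on any further core.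

As far as these compounds go, how a fluoro or methoxy group at this place would compare stays open. So does whether a longer chain on the oxygen would follow either step.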